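The source may hold more compounds than are shown below. What is called first, only, known or untested is meant among the compounds shown, and "the series" means these compounds.

Measured so far:
Compound 1 `Cc1ccc(N2CC(c3nc(-c4cccc(C(F)(F)F)c4)no3)CC2=O)cc1`; in an in vitro functional assay on HEK293-A cells for positive allosteric modulation of metabotropic glutamate receptor 5 (Homo sapiens), read by FLIPR and calcium flux (a higher number here means that more compound is needed for the effect, a lower number that less compound is needed), compound 1 gives 3400 nM.
Compound 2 `Cc1ccccc1N1CC(c2nc(-c3cccc(Cl)c3)no2)CC1=O`; in this assay compound 2 gives > 10000 nM, which is a limit of the assay.

Compound 1 stands at the only number shown in this assay. Compound 2 sits at the limit of > 10000 nM in this assay, at which 1 of the 2 values shown sits. Compound 3 `Cc1ccc(N2CC(c3nc(-c4ccccc4)no3)CC2=O)cc1` differs from compound 1 by hydrogen in place of trifluoromethyl on an aromatic carbon. Among the compounds with values here, no measured step covers this change. In this assay a loss beyond the scatter is expected, and the estimated step is a 2.6-fold higher number from compound 1 to compound 3 (0.42 log units; beyond the scatter). Compound 3 is estimated at 9000 nM, between 3000 nM and 30000 nM, with a fair chance that only a limit is reported.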

Compound 3, half-maximal effective concentration: 384 nM
Compound 3: middle estimate off by 23-fold (1.37 log units), on the high side, and the stated range ends above it.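

In this assay, hydrogen in place of trifluoromethyl on this aromatic carbon gives an 8.9-fold lower number from compound 1 to compound 3 (0.95 log units; beyond the scatter), so the effect does not depend on trifluoromethyl at this place. Within the data shown here, this is the first step that can be read at this position, and the number falls with the change. Nothing shown gives a cause for this step. On these data alone, whether fluorine, a methoxy group or a nitrile on this carbon would give a lower number than hydrogen stays open. So does what an amine there would do.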